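The source may report more compounds than this note shows. Statements on the series, on what has been measured and on what is new or still open speak of the compounds shown alone.

Compound 1, `Cc1cc(/C=C/C#N)cc(C)c1Oc1nc(Nc2ccc(N3CCCC(NS(N)(=O)=O)C3)cc2)nc2ccsc12`, gives > 217000 nM in an ADME assay on MT4 cells (Homo sapiens) for cytotoxicity, read by MTT assay, with a stated time of 5 days (on this read-out higher numbers stand for lower toxicity in this test and lower numbers for higher toxicity in this test), a value that is a limit of the assay and not a number.
Compound 2, `Cc1cc(/C=C/C#N)cc(C)c1Oc1nc(Nc2ccc(CN3CCN(S(C)(=O)=O)CC3)cc2)nc2sccc12`, gives 131000 nM in this assay.

Compound 2 thus holds the only number shown in this assay; the other value recorded is a limit, as the limit of > 217000 nM in this assay, at which 1 of the 2 values shown sits, states. Compound 3, `Cc1cc(/C=C/C#N)cc(C)c1Oc1nc(Nc2ccc(CN3CCNCC3)cc2)nc2sccc12`, differs from compound 2 in one place, by hydrogen in place of methylsulfonyl on an amine nitrogen in a ring. Going by the values given here, no step between two measured compounds is available to calibrate this change, so its size cannot be read from the data. The expected step from compound 2 to compound 3 in this assay is a 1.2-fold lower number from compound 2 to compound 3 (0.08 log units; within the scatter), which the author would not count as beyond the usual scatter. For compound 3 the estimated value in this assay is 110000 nM, with a range from 40000 nM to 250000 nM.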

Compound 3, half-maximal cytotoxic concentration: 4030 nM
Compound 3: the middle estimate sits 27-fold (1.44 log units) above what was measured, outside the stated range (below it).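

In this assay, the methylsulfonyl on the amine nitrogen of the six-membered ring proves to matter: going from (4-(methylsulfonyl)piperazin-1-yl)methyl to (piperazin-1-yl)methyl gives a 33-fold lower number from compound 2 to compound 3 (1.51 log units; beyond the scatter) and so moves the read-out towards higher toxicity in this test. The earlier compounds shown here offered no step to read, and this first one shows that a single change at this position can carry the value well beyond the usual scatter. Nothing measured here gives a reason for the size of this step.

Whether the step follows the loss of methylsulfonyl or the hydrogen that takes its place stays open, since the compounds shown do not tell how a methyl, an acetyl or a longer sulfonyl chain on this nitrogen would read. From the compounds shown here alone, whether the same change would act alike on another core also stays open.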